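The source may report more compounds than this note shows. Statements on the series, on what has been measured and on what is new or still open speak of the compounds shown alone.

Measured so far in a functional assay on KARPAS-299 cells (Homo sapiens) for inhibition, read by CellTiter-Glo, with a stated time of 96 h; on this read-out lower numbers stand for stronger inhibition and higher numbers for weaker inhibition:
- compound 1 `CC(C)S(=O)(=O)c1nn(C)cc1Nc1nc(Nc2ccc(C3CCN(C)CC3)cc2OC2CC2)ncc1Cl` gives 7 nM
- compound 2 `Cc1cc(Nc2ncc(Cl)c(Nc3cn(C)nc3S(=O)(=O)C(C)C)n2)c(OC(C)C)cc1C1CCN(C)C1` gives 11 nM

Among the measured compounds shown here, compound 1 (7 nM) and compound 2 (11 nM) lie within the usual scatter of each other, so the two numbers set no order, and compound 1 stands level with the only other measured compound.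

The next compound to be measured is compound 3 `CC(C)S(=O)(=O)c1nn(C)cc1Nc1nc(Nc2cc(C#N)c(C3CCN(C)CC3)cc2OC2CC2)ncc1Cl`. Against compound 1 it carries one change: cyano in place of hydrogen on an aromatic carbon, with the cyano on an aromatic carbon of a six-membered aromatic ring of carbon only, ortho to a 1-methylpiperidin-4-yl group and para to a cyclopropyloxy group.

For the measured compounds named here, the series holds no measured step between compounds that differ in one place, so nothing measured shows what this change does in this assay. A small move towards weaker inhibition is the working expectation, and no change beyond the scatter remains quite possible. Going by the values given here, the estimated step is a 2.1-fold higher number from compound 1 to compound 3 (0.33 log units; beyond the scatter) and it rests on no precedent. For compound 3 the expected value is 15 nM with an estimated range from 4 nM to 60 nM in this series.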

Compound 3, half-maximal inhibitory concentration: 100 nM
Compound 3: the middle estimate sits 6.7-fold (0.82 log units) below what was measured, outside the stated range (above it).
By their numbers in this assay, from the lowest: compounds 1 and 2 (each within the scatter of the next); then compound 3.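

In this assay, among the compounds shown here, cyano in place of hydrogen on this aromatic carbon, ortho to a 1-methylpiperidin-4-yl group and para to a cyclopropyloxy group, gives a 14-fold higher number from compound 1 to compound 3 (1.15 log units; beyond the scatter) and is the first single-place step available. It shows that this carbon of the six-membered aromatic ring is not a neutral place for substitution on the background of compound 1: a group of just 2 heavy atoms, with no ring and no net charge, moves the read-out clearly towards weaker inhibition. Nothing measured here bears on the origin of this step.

For the compounds shown here, whether this step belongs to cyano itself or to any group on this carbon stays open, since hydrogen and cyano are the only two groups compared here in a single-place step; fluorine, chlorine, methoxy or a primary carboxamide at the same place would separate these readings. Also open, on these data alone, is whether cyano costs as much on a different background, for example with an isopropoxy group in place of the cyclopropyloxy group.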